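Moving the carboxyl on the phenyl ring of compound 3

The compounds below may be only part of what the source reports. "The series", "measured", "known", "first", "only" and "open" are said of these compounds alone.

The series shares a core in which a saturated chain links a carbonyl to an aromatic group. Compound 1 `COC(=O)c1ccccc1CCCCCCC(=O)c1ncc(-c2ccccn2)o1`, which carries a methyl ester, gives 1 nM in an assay for inhibition of Fatty-acid amide hydrolase 1 (Rattus norvegicus); a lower number here means a stronger inhibitor, a higher number a weaker inhibitor. Compound 2 `O=C(CCCCCCc1ccc2ccccc2c1)c1ncc(-c2ccccn2)o1`, with a naphthyl group in place of the phenyl ring, gives 11 nM in this assay. For compound 3 `O=C(CCCCCCc1ccccc1C(=O)O)c1ncc(-c2ccccn2)o1`, this assay reports only a limit, > 600 nM. Compound 3 therefore sits at the weak end of the measured set, at the limit described by the limit of > 600 nM in this assay, at which 1 of the 3 values shown sits. Among the measured compounds shown here, the only measured step that reaches it is an at least 600-fold higher number from compound 1 to compound 3 (2.77 log units; beyond the scatter), the change from methyl ester to free acid.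

Compound 4 `O=C(O)c1cccc(CCCCCCC(=O)c2ncc(-c3ccccn3)o2)c1` differs from compound 3 by 3-carboxyphenyl in place of 2-carboxyphenyl on a saturated chain carbon, six bonds along the chain from a carbonyl carbon. For the measured compounds named here, no measured step compares two positions of the same group on this ring, so the size of the change in this assay cannot be read from the data; the acid in compound 3 already lies at a limit, and a positional move of the same acid is expected to leave the number in a similar region, with the direction open. Compound 4 is accordingly expected to give about 1000 nM in this assay, in a range from 300 nM to 5000 nM, which as a step means a step that the limit leaves unreadable from compound 3 to compound 4.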

Compound 4, inhibition constant: > 600 nM
Compound 4: no number, only a limit (the forecaster's own chance of this, stated with the estimate: 55%); the middle value does not contradict the limit.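

In this assay compound 4 gives > 600 nM as a limit and not a number. Compound 3 also carries only a limit, so no step can be read between compound 3 and compound 4. The compounds shown leave open whether 3-carboxyphenyl in place of 2-carboxyphenyl changes the value at all, and in which direction.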